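Replacing the carbamate on the aryl nitrogen with furanylmethyl

The compounds below may be only part of what the source reports. "The series", "measured", "known", "first", "only" and "open" are said of these compounds alone.

Compound 3 `CCOC(=O)NN(c1ccccc1)[C@H]1c2cc(C#N)ccc2OC(C)(C)[C@@H]1O` carries (ethoxycarbonyl)amino on a nitrogen on an aromatic ring; in a functional assay (aorta) with Rattus norvegicus as the target (on this read-out lower numbers stand for stronger inhibition and higher numbers for weaker inhibition), compound 3 gives 2200 nM, the lowest of the two numbers shown. Compound 1 `CCCCOC(=O)CN(c1ccccc1)[C@H]1c2cc(C#N)ccc2OC(C)(C)[C@@H]1O` bears (butoxycarbonyl)methyl on that nitrogen, and in this assay compound 1 gives 27000 nM. Compound 2 `CCNC(=O)CN(c1ccccc1)[C@H]1c2cc(C#N)ccc2OC(C)(C)[C@@H]1O` has (ethylcarbamoyl)methyl there; in this assay compound 2 gives only the limit > 30000 nM. That value is the limit of > 30000 nM in this assay, at which 1 of the 3 values shown sits. Between the two measured neighbours there is an at least 1.1-fold higher number from compound 1 to compound 2 (0.04 log units; that floor lies within the scatter). Moving to the carbamate gives a 12-fold lower number from compound 1 to compound 3 (1.09 log units; beyond the scatter) and an at least 13-fold lower number from compound 2 to compound 3 (1.13 log units; beyond the scatter), so the substituent on this nitrogen matters a great deal.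

Compound 4 `CC1(C)Oc2ccc(C#N)cc2[C@H](N(Cc2ccco2)c2ccccc2)[C@H]1O` is not yet measured. The change is (furan-2-yl)methyl in place of (ethoxycarbonyl)amino on a nitrogen on an aromatic ring. Among the measured compounds shown here, no measured step covers this group; both measured steps to compound 3 show that other substituents on this nitrogen gave clearly higher numbers. A rise is therefore expected, a 4.5-fold higher number from compound 3 to compound 4 (0.66 log units; beyond the scatter), though its size is uncertain. For compound 4 the estimate in this assay is 10000 nM, within 2000 nM to 40000 nM.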

Compound 4, half-maximal inhibitory concentration: 12000 nM
Beside the measured number, compound 4's estimate is 1.2-fold (0.08 log units) below it; low and high end bracket the measured number.
By their numbers in this assay, from the lowest: compound 3; then compound 4; then compound 1. At a limit, above all of these: compound 2.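

In this assay there is a 5.5-fold higher number from compound 3 to compound 4 (0.74 log units; beyond the scatter), so (ethoxycarbonyl)amino keeps the lowest number of the four compounds, even against a group with the same heavy-atom count. The furan-2-yl group on the saturated chain carbon still improves on both carbonyl-bearing chains, with a 2.3-fold lower number from compound 1 to compound 4 (0.35 log units; beyond the scatter) and an at least 2.5-fold lower number from compound 2 to compound 4 (0.39 log units; beyond the scatter), so the aromatic five-membered ring recovers part of the loss seen with those chains. The value of compound 2 is a limit: the limit of > 30000 nM in this assay, at which 1 of the 4 values shown sits.

On these data alone, how a benzyl group or a 2-aminoethyl chain on this nitrogen would compare in this assay stays open. The four compounds also cannot separate the part played by the carbonyl of the (ethoxycarbonyl)amino group from that of its nitrogen-bound hydrogen.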